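Swapping an aromatic ring for a small saturated ring

The source may report more compounds than this note shows. Statements on the series, on what has been measured and on what is new or still open speak of the compounds shown alone.

Measured so far:
Compound 1, `COc1ccc(CNC(=O)c2cc(-c3cncc(C)c3)ncc2-c2cncc(F)c2)nc1OC`: 17000 nM
Compound 2, `COc1ccc(CNC(=O)c2sc(-c3cncc(C)c3)nc2-c2cccc(F)c2)nc1OC`: 12000 nM
Compound 3, `COc1ccc(CNC(=O)c2nc(-c3cncc(C)c3)ncc2-c2ccccc2)nc1OC`: 23000 nM

Three compounds share the same dimethoxypyridine amide arm and the same 5-methylpyridin-3-yl group, and differ in the shared core and in the aromatic ring attached ortho to the amide. In an assay on CHO cells for displacement of a labelled ligand from Orexin/Hypocretin receptor type 1 variant I408V (Homo sapiens), read by scintillation counting (a lower number here means a stronger inhibitor, a higher number a weaker inhibitor), compound 1 gives 17000 nM. Compound 2 gives 12000 nM and compound 3 gives 23000 nM in this assay. Compound 1 has the second highest of the three numbers, but its gaps to compound 3 and to compound 2 both lie within the usual scatter, so the three are best read as equally weak inhibitors.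

Compound 4, `COc1ccc(CNC(=O)c2cc(-c3cncc(C)c3)ncc2N2CCC2)nc1OC`, is the next compound, not yet measured. It differs from compound 1 in one place: azetidin-1-yl in place of 5-fluoropyridin-3-yl on an aromatic carbon. The ring that leaves is aromatic and carries a fluorine; the ring that enters is a small saturated ring joined through its nitrogen. Among the compounds with values here, no measured pair shows a comparable change, so there is no step to lean on. Because compound 1 gives 17000 nM and compound 2 and compound 3 give weak numbers close to it despite their different aromatic rings, compound 4 is expected to land in the same weak region. The step expected here is a 1.1-fold lower number from compound 1 to compound 4 (0.05 log units; within the scatter), roughly within the scatter. Compound 4 is estimated at 15000 nM, in a range from 4000 nM to 60000 nM.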

Compound 4, inhibition constant: 18000 nM
Compound 4: the middle estimate sits 1.2-fold (0.08 log units) below what was measured, and the stated range covers the measured number.
By their numbers in this assay, from the lowest: compounds 2, 1, 4 and 3 (each within the scatter of the next).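

In this assay, putting azetidin-1-yl in place of 5-fluoropyridin-3-yl gives a 1.1-fold higher number from compound 1 to compound 4 (0.02 log units; within the scatter), so the two compounds read as the same. The earlier compounds shown here all carried an aromatic ring at this place, ortho to a large group and para to a 5-methylpyridin-3-yl group, whereas compound 4 shows that a four-membered non-aromatic ring with fewer heavy atoms also stays in the same weak region, so an aromatic ring here is not what sets the number within this set. Nothing measured on these compounds says why the two numbers match.

The compounds shown leave open whether a different kind of group at this place, such as an open-chain amine or a carboxylic acid, would give a number clearly apart from this weak region. All four compounds also share the dimethoxypyridine amide arm and the 5-methylpyridin-3-yl group, so what a different group at either of those places would do remains an open question.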